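The source may hold more compounds than are shown below. What is called first, only, known or untested is meant among the compounds shown, and "the series" means these compounds.

Compound 2 `Cc1cc(C)c(CN2CCc3c(Cl)cc([C@@H](CO)[C@H]4CCCO4)c(Cl)c3C2=O)c(=O)[nH]1` is one of two compounds with a single number in an ADME assay on microsomes from liver (Homo sapiens) for metabolic stability, read by LC-MS, using NADPH, with stated times of 10 min and 45 min, tested at 1 uM (on this read-out lower numbers stand for slow clearance and higher numbers for fast clearance), where compound 2 gives 43 uL/min, the higher of the two. Compound 1 `Cc1cc(C)c(CN2CCc3c(Cl)cc([C@@H](C)CO)c(Cl)c3C2=O)c(=O)[nH]1` gives 12.4 uL/min, and the step of a 3.5-fold higher number from compound 1 to compound 2 (0.54 log units; beyond the scatter). Compound 3 `COC(c1cc(Cl)c2c(c1Cl)C(=O)N(Cc1c(C)cc(C)[nH]c1=O)CC2)C1CCS(=O)(=O)CC1` has two entries, 15 uL/min; 40 uL/min (2 entries), and the several entries of compound 3 in this assay, 15 uL/min; 40 uL/min (2 entries) show how far repeats of this kind can differ. Compound 4 `Cc1cc(C)c(CN2CCc3c(Cl)cc([C@H](CO)[C@H]4CCCO4)c(Cl)c3C2=O)c(=O)[nH]1` is the next compound: the two compounds have the same atoms and bonds and differ only in configuration as drawn: 1 of 2 stereo elements differ; a stereocentre at a saturated chain carbon is drawn S in compound 2 and R in compound 4. For the measured compounds named here, no measured step concerns a change of configuration alone, so the swap of one group for another between compound 1 and compound 2 does not bear on it. For compound 4 the expected step is therefore no change at the digits printed from compound 2 to compound 4 (within the scatter), within the scatter. Compound 4 is estimated at 43 uL/min, with a range from 20 uL/min to 90 uL/min.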

Compound 4, intrinsic clearance in a liver preparation (reported as CLH), per the amount of preparation that the assay uses: 51.6 uL/min
Compound 4: middle estimate off by 1.2-fold (0.08 log units), on the low side, and the stated range covers the measured number.
By their numbers in this assay, from the lowest: compound 1; then compounds 2 and 4 (each within the scatter of the next).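

In this assay, swapping the drawn configuration at the saturated chain carbon gives a 1.2-fold higher number from compound 2 to compound 4 (0.08 log units; within the scatter), so this position shows no measurable dependence on that configuration. Oxolan-2-yl in place of methyl on that carbon gives a 4.2-fold higher number from compound 1 to compound 4 (0.62 log units; beyond the scatter), so the higher clearance seen with this group holds in both drawn configurations. Such a small gap must be read against how far repeats can differ: the several entries of compound 3 in this assay, 15 uL/min; 40 uL/min (2 entries)

Open, going by these compounds, is whether the second stereo element, shared by these two compounds, matters. Also open, on these data alone, is whether an amine or a carboxylic acid in place of oxolan-2-yl would give a lower number.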